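The compounds below may be only part of what the source reports. "The series", "measured", "known", "first", "only" and "open" are said of these compounds alone.

- Compound 1 `O=C(Nc1ccccc1)C1CCN(C/C=C/c2ccccc2)CC1`: 60200 nM
- Compound 2 `CCCc1ccc(NC(=O)C2CCN(C/C=C/c3ccccc3)CC2)cc1`: 9030 nM
- Compound 3 `CC(C)c1ccc(NC(=O)C2CCN(C/C=C/c3ccccc3)CC2)cc1`: 9100 nM

In a functional assay on MCF7 cells (Homo sapiens) for inhibition, read by MTT assay, with a stated time of 72 h (a lower number here means a stronger inhibitor, a higher number a weaker inhibitor), compound 3 gives 9100 nM. Placing isopropyl on the ring gave a 6.6-fold lower number from compound 1 to compound 3 (0.82 log units; beyond the scatter), and propyl gave a similar a 6.7-fold lower number from compound 1 to compound 2 (0.82 log units; beyond the scatter). Exchanging one chain for the other gave a 1.0-fold higher number from compound 2 to compound 3 (0.00 log units; within the scatter).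

Compound 4 `CCCCc1ccc(NC(=O)C2CCN(C/C=C/c3ccccc3)CC2)cc1` carries butyl in place of isopropyl on an aromatic carbon, para to a large group: butyl in place of isopropyl on an aromatic carbon. For the measured compounds named here, the closest precedent is the exchange that gave a 1.0-fold higher number from compound 2 to compound 3 (0.00 log units; within the scatter), so no change beyond the scatter is expected. The expected step is a 1.2-fold lower number from compound 3 to compound 4 (0.08 log units; within the scatter). Compound 4 is estimated at 7500 nM, with an expected range of 3500 nM to 16000 nM.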

Compound 4, half-maximal inhibitory concentration: 5870 nM
The estimate for compound 4 lay 1.3-fold (0.11 log units) above the measured number; low and high end bracket the measured number.
By their numbers in this assay, from the lowest: compounds 4, 2 and 3 (each within the scatter of the next); then compound 1.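

In this assay butyl sits level with the shorter chains on this aromatic carbon, with a 1.6-fold lower number from compound 3 to compound 4 (0.19 log units; within the scatter) and a 1.5-fold lower number from compound 2 to compound 4 (0.19 log units; within the scatter) both remaining within the scatter. Against hydrogen at the same place, butyl gives a 10-fold lower number from compound 1 to compound 4 (1.01 log units; beyond the scatter) and this is the only step so far rated large, although the three chains cannot be told apart from one another. No supporting evidence bears on this result.

The compounds shown leave open whether a chain longer than butyl would hold this level. They also leave open how an amine or a carboxylic acid at this place would compare.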